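Thiosemicarbazone series: dimethylamino on the aryl ring

The source may report more compounds than this note shows. Statements on the series, on what has been measured and on what is new or still open speak of the compounds shown alone.

Compound 1 `CC1=CC[C@H](C(C)(C)NC(=S)NN)CC1` gives 41900 nM in a functional assay on OVCAR-3 cells (Homo sapiens) for inhibition, read by sulforhodamine B assay, with a stated time of 48 h; a higher number here means a weaker inhibitor of growth, a lower number a stronger inhibitor of growth. Within the data shown here, compound 2 `CC1=CC[C@H](C(C)(C)NC(=S)N/N=C/c2ccccc2)CC1` gives 8700 nM in this assay, the lowest of the two numbers so far, with compound 1 standing clearly higher. Compound 3 `CC1=CC[C@H](C(C)(C)NC(=S)N/N=C/c2ccc(N(C)C)cc2)CC1` differs from compound 2 by dimethylamino in place of hydrogen on an aromatic carbon. Among the measured compounds shown here, no comparable step has been measured in this set, so the size of the change is open; the expectation is for a step in this assay of no more than modest size, if anything toward a lower number. Compound 3 is estimated at 5000 nM, between 1500 nM and 20000 nM. The step of a 1.7-fold lower number from compound 2 to compound 3 (0.24 log units; within the scatter) is expected to stay small.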

Compound 3, concentration for 50% growth inhibition: > 100000 nM
Compound 3: only a limit was reported; the forecaster's own chance of this, stated with the estimate: 3%; middle value at least 20-fold (1.30 log units) from the limit.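

Dimethylamino in place of hydrogen on an aromatic carbon, para to a large group, brings an at least 11-fold higher number from compound 2 to compound 3 (1.06 log units; beyond the scatter) in this assay. Among these compounds, this is the first sign that this position is not indifferent to substitution, and the change goes toward weaker growth inhibition. Compound 3 carries only a limit of the assay, so the full size of the step stays unknown: the limit of > 100000 nM in this assay, at which 1 of the 3 values shown sits.

On these data alone, whether this loss is particular to dimethylamino or follows from any group at this position remains open. A primary amine, a methoxy group or a fluorine atom on the same carbon would separate the two readings.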